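Propargyloxycarbonyl in place of propargyl on the sulfonamide nitrogen

The source may hold more compounds than are shown below. What is called first, only, known or untested is meant among the compounds shown, and "the series" means these compounds.

Measured compounds:
compound 1 `CCOC(=O)C1=CCCCC1S(=O)(=O)N(Cc1ccc([N+](=O)[O-])cc1)c1ccc(F)cc1Cl`: 1790 nM
compound 2 `C#CCN(c1ccc(F)cc1Cl)S(=O)(=O)C1CCCC=C1C(=O)OCC`: 334 nM

In an assay on cells for inhibition of Toll-like receptor 4 (Homo sapiens), read by reporter gene assay, with stated times of 1 h and 22 h (on this read-out higher numbers stand for weaker inhibition and lower numbers for stronger inhibition), compound 2 gives the lowest of the two numbers; its nearest neighbour is compound 1, and the step of a 5.4-fold lower number from compound 1 to compound 2 (0.73 log units; beyond the scatter) lies beyond the scatter. Compound 3 `C#CCOC(=O)N(c1ccc(F)cc1Cl)S(=O)(=O)C1CCCC=C1C(=O)OCC` differs from compound 2 by propargyloxycarbonyl in place of propargyl on a sulfonamide nitrogen. Among the measured compounds shown here, no measured step alters this nitrogen in the same way; the only step recorded, a 5.4-fold lower number from compound 1 to compound 2 (0.73 log units; beyond the scatter), changes the group on that nitrogen and was modest. A step of similar or smaller size is therefore expected, most likely towards a higher number, as a 2.1-fold higher number from compound 2 to compound 3 (0.32 log units; beyond the scatter). Compound 3 is estimated at 700 nM, within 200 nM to 2500 nM.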

Compound 3, half-maximal inhibitory concentration: 3900 nM
Compound 3: middle estimate off by 5.6-fold (0.75 log units), on the low side, and the stated range ends below it.
By their numbers in this assay, from the lowest: compound 2; then compound 1; then compound 3.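

In this assay, the sulfonamide nitrogen proves sensitive to the group it carries: a 12-fold higher number from compound 2 to compound 3 (1.07 log units; beyond the scatter) is a large step, whereas the earlier change at this nitrogen was modest. Keeping the propargyl unit within the new group therefore does not preserve the lower number, and a 2.2-fold higher number from compound 1 to compound 3 (0.34 log units; beyond the scatter) places propargyloxycarbonyl above even 4-nitrobenzyl. The data at hand offer no account of this shift. On these data alone, it remains open whether the carbonyl or the added oxygen carries the loss, and how an acetyl group or a simple methyl on this nitrogen would read.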